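Methyl for methoxy on a chlorinated core: expected weaker inhibition

This account rests on a few compounds, and the source may have more. Where it says the series, first, only, none or still open, it means among the compounds named here.

Compound 1 `CCN(CC)CN1C(=O)/C(=N/NC(=S)Nc2ccc(OC)cc2)c2ccccc21` is the reference point of this small set. In a functional assay on CCRF-CEM cells (Homo sapiens) for inhibition, read by cell counting, with a stated time of 72 h (a higher number here means a weaker inhibitor, a lower number a stronger inhibitor), compound 1 gives 1900 nM. Compound 2 `CCN(CC)CN1C(=O)/C(=N/NC(=S)Nc2ccc(C)cc2)c2ccccc21` differs from it by methyl in place of methoxy on an aromatic carbon, and this change brought a 6.3-fold higher number from compound 1 to compound 2 (0.80 log units; beyond the scatter). Compound 3 `CCN(CC)CN1C(=O)/C(=N/NC(=S)Nc2ccc(OC)cc2)c2cc(Cl)ccc21` carries the core of compound 1 altered by chloro in place of hydrogen on an aromatic carbon, with a 3.6-fold higher number from compound 1 to compound 3 (0.56 log units; beyond the scatter). In this assay compound 2 gives 12000 nM and compound 3 gives 6900 nM, and these two numbers lie within the scatter of each other.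

Compound 4 `CCN(CC)CN1C(=O)/C(=N/NC(=S)Nc2ccc(C)cc2)c2cc(Cl)ccc21` is not yet measured. It differs from compound 3 by methyl in place of methoxy on an aromatic carbon, the same change that led from compound 1 to compound 2, now made on the core of compound 3. Because the first occurrence gave a 6.3-fold higher number from compound 1 to compound 2 (0.80 log units; beyond the scatter), compound 4 is expected to be a weaker inhibitor than compound 3, with an estimated step of a 4.3-fold higher number from compound 3 to compound 4 (0.64 log units; beyond the scatter) in this assay. Within the data shown here, with only one prior example of this change, the estimate for compound 4 is 30000 nM, expected to lie between 10000 nM and 90000 nM.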

Compound 4, half-maximal inhibitory concentration: 4600 nM
Compound 4: the middle estimate sits 6.5-fold (0.81 log units) above what was measured, and the stated range ends above it.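

In this assay, methyl in place of methoxy did not carry over from the core of compound 1 to the chlorinated core, where it gave a 1.5-fold lower number from compound 3 to compound 4 (0.18 log units; within the scatter), and the two occurrences differ: the same change on two cores in this assay, a 6.3-fold higher number (0.80 log units; beyond the scatter) from compound 1 to compound 2 and a 1.5-fold lower number (0.18 log units; within the scatter) from compound 3 to compound 4, 9.5-fold (0.98 log units) apart, beyond the scatter of two such steps. Read the other way round, chloro in place of hydrogen gave a 2.6-fold lower number from compound 2 to compound 4 (0.42 log units; beyond the scatter), which also departs from its earlier occurrence: the same change on two cores in this assay, a 3.6-fold higher number (0.56 log units; beyond the scatter) from compound 1 to compound 3 and a 2.6-fold lower number (0.42 log units; beyond the scatter) from compound 2 to compound 4, 9.5-fold (0.98 log units) apart, beyond the scatter of two such steps. These four compounds show that, in this set, the result of each change depends on the other, but they do not show why, and this single pair of cores gives no rule for any other core.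

On these data alone, it remains open whether other groups on the aromatic ring, such as an ethoxy group, a fluoro group or a hydroxyl group, would follow the methoxy or the methyl result on the two cores. Also open, as far as these compounds go, is whether bromo in place of chloro, or a morpholine in place of the diethylamine, would change the picture.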